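The source may report more compounds than this note shows. Statements on the series, on what has been measured and on what is new or still open speak of the compounds shown alone.

Measured compounds:
Compound 1 `COC(=O)c1sc2cc(-c3ccoc3)cnc2c1N` in a functional assay on NCI-H460 cells (Homo sapiens) for inhibition, read by sulforhodamine B assay, with a stated time of 48 h (on this read-out lower numbers stand for stronger inhibition of growth and higher numbers for weaker inhibition of growth), gives > 120000 nM, which is a limit of the assay.
Compound 2 `COC(=O)c1sc2cc(-c3cnn(C)c3)cnc2c1N` in this assay gives > 150000 nM, likewise a limit.

Compound 2 therefore stands only at a limit, with no exact number. Among the measured compounds shown here, the one measured step, a step that the two limits leave unreadable from compound 1 to compound 2, rests on the limit of > 120000 nM in this assay, at which 1 of the 2 values shown sits, and the limit of > 150000 nM in this assay, at which 1 of the 2 values shown sits, and so has no readable size. Compound 3 `COC(=O)c1sc2cc(-c3cccnc3)cnc2c1N` differs from compound 2 by pyridin-3-yl in place of 1-methyl-1H-pyrazol-4-yl on an aromatic carbon. With no readable step to guide it, no change beyond the scatter is expected in this assay. Compound 3 is therefore expected at 150000 nM, with a range from 50000 nM to 400000 nM. This corresponds to an expected step of a number no higher from compound 2 to compound 3 (the limit leaves the size open).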

Compound 3, concentration for 50% growth inhibition: > 112000 nM
Compound 3: no number, only a limit; the forecaster's own chance of this, stated with the estimate: 80%; the middle value lies beyond the limit too.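

Among the compounds shown here, compound 1, compound 2 and compound 3 each give only a limit, so no step among them can be read. Going by these compounds, whether furan-3-yl, 1-methyl-1H-pyrazol-4-yl or pyridin-3-yl differ in their effect on growth this assay stays open.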